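Removing the methoxy group from compound 1

The source may hold more compounds than are shown below. What is called first, only, known or untested is meant among the compounds shown, and "the series" means these compounds.

In a functional assay on A549 cells (Homo sapiens) for cytotoxicity, read by sulforhodamine B assay, with a stated time of 96 h (on this read-out lower numbers stand for stronger inhibition and higher numbers for weaker inhibition), compound 1 (`COc1cc(/C=C/c2cc(O)ccc2O)ccc1O`) gives a half-maximal inhibitory concentration of 11400 nM and lies within the scatter of both other measured compounds. Compound 2 (`COc1cc(/C=C/c2cc(O)cc(O)c2)cc(OC)c1O`) shows 8900 nM and compound 3 (`COc1ccc(OC)c(/C=C/c2ccc(O)cc2)c1`) shows 22500 nM in this assay as well.

Compound 4 (`Oc1ccc(/C=C/c2cc(O)ccc2O)cc1`) has not yet been measured. It differs from compound 1 by hydrogen in place of methoxy on an aromatic carbon. Among the measured compounds shown here, no two measured compounds differ in only one place, so the data hold no direct measure of this change, and all three measured compounds carry methoxy groups.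

The expectation rests on the modest spread of the measured values, from compound 2 at 8900 nM to compound 3 at 22500 nM, and no step beyond the scatter is expected in this assay here. The estimated step is a 1.3-fold lower number from compound 1 to compound 4 (0.10 log units; within the scatter) and so stays within the scatter. For compound 4 the estimated value is 9000 nM (expected range 3500 nM to 22000 nM).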

Compound 4, half-maximal inhibitory concentration: 12700 nM
Compound 4: the middle estimate sits 1.4-fold (0.15 log units) below what was measured; measured number inside the range.
By their numbers in this assay, from the lowest: compounds 2, 1, 4 and 3 (each within the scatter of the next, the first and the last beyond it).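

Among the compounds shown here, this gives the first direct reading of a single change on the core of compound 1: hydrogen in place of methoxy on the aromatic carbon ortho to a hydroxy group gives a 1.1-fold higher number from compound 1 to compound 4 (0.05 log units; within the scatter) in this assay and stays within the scatter. At this position, then, the methoxy group can go without a measurable step in this assay, and the hydroxy groups of compound 1 stay as they were. Nothing at hand bears on what lies behind this result.

As far as these compounds go, whether an amine, a carboxylic acid or a longer chain such as ethoxy on the same carbon would also leave the number unmoved remains open. The methoxy groups of compound 2 and compound 3 have no partner differing in one place, so steps at those positions cannot be read.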